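The source may hold more compounds than are shown below. What is called first, only, known or untested is meant among the compounds shown, and "the series" means these compounds.

For the measured compounds named here, in a functional assay on CHO cells for agonist activity at 5-hydroxytryptamine receptor 4 (Homo sapiens), read by a luciferase reporter and cAMP accumulation, with a stated time of 4 h (on this read-out lower numbers stand for an effect already at smaller amounts and higher numbers for an effect only at larger amounts of compound), compound 2 `CC(C)c1nc(C(=O)NCC2(O)CCN(CC3CCOCC3)CC2)c2ccccn12` gives 56.7 nM, the lowest of the three numbers so far. Compound 3 `CC(C)c1nc(C(=O)NCC2(O)CCN(CC(C)(C)O)CC2)c2ccccn12` gives 72.3 nM, and the step here is a 1.3-fold higher number from compound 2 to compound 3 (0.11 log units; within the scatter). Compound 1 `COCCCN1CCC(O)(CNC(=O)c2nc(C(C)C)n3ccccc23)CC1` gives 316 nM; the steps from it are a 5.6-fold lower number from compound 1 to compound 2 (0.75 log units; beyond the scatter) and a 4.4-fold lower number from compound 1 to compound 3 (0.64 log units; beyond the scatter). Compound 4 `CC(C)c1nc(C(=O)NCC2(C)CCN(CC3CCOCC3)CC2)c2ccccn12` differs from compound 2 by methyl in place of hydroxy on a saturated ring carbon. Going by the values given here, all three measured steps alter the group on a saturated chain carbon bound to an amine nitrogen in a ring, and none touches the saturated ring carbon changed here, so no measured step bears on this change. Compound 4 is estimated at 150 nM, with a range from 40 nM to 600 nM. The expected step is a 2.6-fold higher number from compound 2 to compound 4 (0.42 log units; beyond the scatter), an expectation not anchored by any measured step.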

Compound 4, half-maximal effective concentration: 53 nM
The estimate for compound 4 lay 2.8-fold (0.45 log units) above the measured number, and the stated range covers the measured number.
By their numbers in this assay, from the lowest: compounds 4, 2 and 3 (each within the scatter of the next); then compound 1.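

In this assay, methyl in place of hydroxy on this saturated ring carbon, three ring bonds from the ring nitrogen, gives a 1.1-fold lower number from compound 2 to compound 4 (0.03 log units; within the scatter) and so leaves the two numbers within the scatter of each other. The hydrogen-bond donor and acceptor counted for hydroxy are therefore not needed at this position for this number, at least with the (oxan-4-yl)methyl group present. No measurement here gives a reason for this result.

The compounds shown leave open how an amine or a fluorine on this ring carbon would read. They also leave open whether methyl in place of hydroxy gives the same result in compound 1 or compound 3.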